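Swapping a pyridine for a methoxyphenyl on the shared core

The source may report more compounds than this note shows. Statements on the series, on what has been measured and on what is new or still open speak of the compounds shown alone.

Measured so far:
Compound 1, `Cc1cc(NC(=O)Cn2nnc(-c3ccccc3)n2)n(C2CCS(=O)(=O)CC2)n1`: in an assay on HEK293 cells for activation of Kir3.1/Kir3.2 (Homo sapiens), read by thallium flux (on this read-out higher numbers stand for larger maximal responses and lower numbers for smaller maximal responses), compound 1 gives > 25%.
Compound 2, `Cc1nc(NC(=O)Cn2nnc(-c3ccccc3)n2)n(-c2ccccc2)n1`: in this assay compound 2 is reported as "not active" (no number reported).
Compound 3, `Cc1cc(NC(=O)Cn2nnc(-c3ccccn3)n2)n(C2CCCCC2)n1`: in this assay compound 3 gives 81%.

The value of compound 1 is a limit of the assay and not a number (the limit of > 25% in this assay, at which 1 of the 3 values shown sits). Compound 2 has no number at all. So compound 3 holds the only real number in this set, and nothing can be said about how it ranks against the other two.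

Compound 4, `COc1ccc(-c2nnn(CC(=O)Nc3cc(C)nn3C3CCCCC3)n2)cc1`, has not been measured. It differs from compound 3 in one place: 4-methoxyphenyl in place of pyridin-2-yl on an aromatic carbon. Compound 1 and compound 2 also carry a carbon-only ring at that position, but each differs from compound 3 elsewhere as well, so no single step can be read from them.

Without a measured step to lean on, a moderate change in this assay seems the most reasonable expectation, and the estimated step from compound 3 to compound 4 is a number 21 percentage points lower from compound 3 to compound 4 (beyond the scatter), a downward move beyond the usual scatter but far from loss of activity. For compound 4 the expected value is 60%, with a range from 20% to 95%.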

Compound 4, largest response reached (Emax), in percent of the reference or control that the assay uses: 90%
The estimate for compound 4 lay 30 percentage points below the measured number, and the stated range covers the measured number.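

In this assay, replacing pyridin-2-yl with 4-methoxyphenyl on the aromatic carbon of the five-membered ring gives a number 9 percentage points higher from compound 3 to compound 4 (within the scatter), so the two groups cannot be told apart on this read-out. Within the data shown here, this is the first clean look at this position, and it shows that a ring of carbon only can sit there with no ring nitrogen in that group: compound 4 gives 90%, a large maximal response that compound 1 and compound 2 could not reveal, since each also differs from compound 3 elsewhere. No measured property of either group bears on this result, so the data give no reason why the swap is tolerated.

The compounds shown leave open whether the methoxy group matters at all, since a plain phenyl ring on exactly the core of compound 3 is not among them. They also leave open how far this tolerance extends, for example to a phenyl ring carrying an amine or a carboxylic acid in place of the methoxy group.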